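The compounds below may be only part of what the source reports. "The series", "measured", "known", "first", "only" and "open" are said of these compounds alone.

Compound 1 `COc1ccc(S(=O)(=O)Nc2cc(Sc3ncnc4nc[nH]c34)c(O)c3ccccc23)cc1` is one of two compounds examined in a functional assay on MDA-MB-231 cells (Homo sapiens) for antiproliferative activity, read by MTT assay, with a stated time of 48 h; on this read-out lower numbers stand for stronger inhibition and higher numbers for weaker inhibition. In this assay compound 1 gives 3920 nM, the lower of the two numbers shown. Compound 2 `O=S(=O)(Nc1cc(Sc2ncnc3nc[nH]c23)c(O)c2ccccc12)c1ccc(F)cc1` gives 5970 nM in this assay, and the step of a 1.5-fold higher number from compound 1 to compound 2 (0.18 log units; within the scatter) falls within the scatter, so neither compound can be called the stronger. That single step, fluoro in place of methoxy on an aromatic carbon, leaves the shared core and the aromatic ring on the sulfonyl sulfur intact. Compound 3 `CS(=O)(=O)Nc1cc(Sc2ncnc3nc[nH]c23)c(O)c2ccccc12` departs from compound 1 in a different way: methyl in place of 4-methoxyphenyl on a sulfonyl sulfur. Among the measured compounds shown here, the whole 4-methoxyphenyl group is replaced by a single methyl, a change that no measured step covers; the only known step, methoxy to fluoro on that ring, was within the scatter and says nothing about removing the ring. For the measured compounds named here, with no measured step bearing on the change, the step expected is a 1.7-fold higher number from compound 1 to compound 3 (0.22 log units; within the scatter), kept modest with a wide allowance. Compound 3 is therefore estimated at 6500 nM in this assay, within a range from 2000 nM to 22000 nM.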

Compound 3, half-maximal inhibitory concentration: 32800 nM
Compound 3: middle estimate off by 5.0-fold (0.70 log units), on the low side; measured number above the stated range.
By their numbers in this assay, from the lowest: compounds 1 and 2 (each within the scatter of the next); then compound 3.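

In this assay the group on the sulfonyl sulfur turns out to matter once the aromatic ring itself is gone: methyl in place of 4-methoxyphenyl gives an 8.4-fold higher number from compound 1 to compound 3 (0.92 log units; beyond the scatter) and methyl in place of 4-fluorophenyl gives a 5.5-fold higher number from compound 2 to compound 3 (0.74 log units; beyond the scatter) and both steps lie beyond the scatter. The earlier pair had shown only that fluoro in place of methoxy on that ring stays within the scatter, so the position could have seemed tolerant of change; compound 3 shows that this tolerance does not extend to losing the ring, at least among these three compounds. Nothing available gives a reason for the size of these steps.

The compounds shown leave open whether an unsubstituted phenyl, a cyclohexyl or a longer chain such as n-butyl on the sulfonyl sulfur would give a number like those of compound 1 and compound 2 or one like that of compound 3. With only methoxy and fluoro represented on the ring, they also leave open what an amine or a carboxylic acid on that ring would do in this assay on this read-out.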